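The compounds below may be only part of what the source reports. "The series", "measured", "known", "first", "only" and "open" are said of these compounds alone.

Measured in an assay on Sf9 cells for inhibition of mitogen-activated protein kinase kinase kinase 14 variant S549D (Homo sapiens), with a stated time of 30 min, in the presence of a further agent that is not named here; on this read-out higher numbers stand for weaker inhibition and lower numbers for stronger inhibition:

compound 1, `C=Cc1ccnc(C#Cc2ccc3ncn(-c4ccnc(N)n4)c3c2)c1`: 1580 nM
compound 2, `C#Cc1ccnc(C#Cc2ccc3ncn(-c4ccnc(N)n4)c3c2)c1`: 316 nM
compound 3, `C=Cc1nccc(C#Cc2ccc3ncn(-c4ccnc(N)n4)c3c2)n1`: 39800 nM

All three share one core and differ only in the group carried on the triple-bonded carbon. Compound 2 differs from compound 1 by ethynyl in place of vinyl on an aromatic carbon, and this change gave a 5.0-fold lower number from compound 1 to compound 2 (0.70 log units; beyond the scatter). Compound 3 differs from compound 1 by a group of 8 heavy atoms (6 carbon, 2 nitrogen; one six-membered aromatic ring with 2 hetero atoms) in place of a group of 8 heavy atoms (7 carbon, 1 nitrogen; one six-membered aromatic ring with 1 hetero atom), on a triple-bonded carbon; the result was a 25-fold higher number from compound 1 to compound 3 (1.40 log units; beyond the scatter), and against compound 2 it reads a 130-fold higher number from compound 2 to compound 3 (2.10 log units; beyond the scatter). Compound 3 therefore has the highest number of the three, and both of its steps lie beyond the scatter.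

Compound 4, `C#Cc1nccc(C#Cc2ccc3ncn(-c4ccnc(N)n4)c3c2)n1`, has not yet been measured. It differs from compound 3 by ethynyl in place of vinyl on an aromatic carbon. Going by the values given here, this is the same kind of change as the one from compound 1 to compound 2, but not the same: in compound 1 the place is on a six-membered aromatic ring with 1 nitrogen, opposite the ring nitrogen, while in compound 3 it is on a six-membered aromatic ring with 2 nitrogen, between two ring nitrogen atoms.

Among the compounds with values here, for compound 4 the expected step is a 4.0-fold lower number from compound 3 to compound 4 (0.60 log units; beyond the scatter), resting on the single earlier example a 5.0-fold lower number from compound 1 to compound 2 (0.70 log units; beyond the scatter). That example is taken with caution: the surroundings of the place differ. The estimate for compound 4 in this assay is 10000 nM, expected to fall between 3000 nM and 40000 nM.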

Compound 4, half-maximal inhibitory concentration: 39800 nM
Estimate against measurement, compound 4: 4.0-fold (0.60 log units) below; measured number inside the range.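

In this assay, the swap of vinyl for ethynyl that gave stronger inhibition on the ring with 1 nitrogen did nothing measurable on the ring with 2 nitrogen, where the step reads no change at the digits printed from compound 3 to compound 4 (within the scatter), and the two examples of this one change disagree: the same change on two cores in this assay, a 5.0-fold lower number (0.70 log units; beyond the scatter) from compound 1 to compound 2 and no change at the digits printed (within the scatter) from compound 3 to compound 4, 5.0-fold (0.70 log units) apart, beyond the scatter of two such steps

An improvement seen on one core therefore cannot be assumed on the other in this series, and the choice of ring weighs more here than the choice between vinyl and ethynyl, since the ring with 2 nitrogen costs a great deal even with ethynyl in place, at a 130-fold higher number from compound 2 to compound 4 (2.10 log units; beyond the scatter), and the comparison with the vinyl compound reads a 25-fold higher number from compound 1 to compound 4 (1.40 log units; beyond the scatter). Going by these compounds alone, this rests on only one pair of compounds per core, so it does not show why the two cores respond differently, or how the swap would behave on any third core.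

The compounds shown carry only vinyl or ethynyl on these two rings, so it remains open how an amine, a nitrile or a longer chain such as propynyl would read on either ring. They also leave open whether the ethynyl improvement would survive a change elsewhere on the shared core, such as replacing its amine with a methyl group.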